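This account rests on a few compounds, and the source may have more. Where it says the series, first, only, none or still open, it means among the compounds named here.

The measured compounds:

compound 1, `Cc1cccc(CN2CCC(c3noc(COc4ccc(/C=C/C(=O)NO)cc4)n3)CC2)c1`: 73%
compound 2, `O=C(/C=C/c1ccc(OCc2nc(C3CCN(Cc4ccccc4F)CC3)no2)cc1)NO`: 68%
compound 3, `Cc1cccc(CN2CCC(c3noc(CN(C)c4ncc(C(=O)NO)cn4)n3)CC2)c1`: 54%

Three compounds were tested in an assay on isolated protein for inhibition of protein deacetylase HDAC6 (Homo sapiens), read by fluorescence, with a stated time of 1 h, tested at 100 nM; on this read-out higher numbers stand for more inhibition at the one concentration tested (going by the name of the read-out) and lower numbers for less inhibition. In that assay compound 1 gives 73%, and compound 2 gives 68%. Compound 2 differs from compound 1 by a single change, (2-fluorophenyl in place of 3-methylphenyl on a saturated chain carbon bound to an amine nitrogen in a ring), and the read-out moved by a number 5 percentage points lower from compound 1 to compound 2 (within the scatter), so the two numbers are not distinguishable from one another.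

Compound 3 gives 54% in this assay . Its core is not the core of compound 1; the difference between the two cores is not broken down here. Compound 3 stands lowest of the three measured numbers, and its gaps to compound 2 and to compound 1 both lie beyond the usual scatter.

Compound 4, `CN(Cc1nc(C2CCN(Cc3ccccc3F)CC2)no1)c1ncc(C(=O)NO)cn1`, has not yet been measured. It stands to compound 3 as compound 2 stands to compound 1, carrying the same change, (2-fluorophenyl in place of 3-methylphenyl on a saturated chain carbon bound to an amine nitrogen in a ring), at the same place. Because the earlier occurrence of this change produced a number 5 percentage points lower from compound 1 to compound 2 (within the scatter), compound 4 is expected to sit close to compound 3, with the step estimated at a number 4 percentage points lower from compound 3 to compound 4 (within the scatter). On that basis compound 4 is estimated to give 50% in this assay , expected to fall between 36% and 63%.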

Compound 4, a percentage reported as inhibition, at one concentration (the size of the read-out at that concentration, not a potency): 44%
Estimate against measurement, compound 4: 6 percentage points above; low and high end bracket the measured number.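

In this assay, 2-fluorophenyl in place of 3-methylphenyl on a saturated chain carbon bound to an amine nitrogen in a ring gives a number 10 percentage points lower from compound 3 to compound 4 (within the scatter), so the two numbers cannot be told apart. Set beside the earlier step, the change reads alike on the two cores: the same change on two cores in this assay, a number 5 percentage points lower (within the scatter) from compound 1 to compound 2 and a number 10 percentage points lower (within the scatter) from compound 3 to compound 4, 5 percentage points apart, within the scatter of two such steps. For the compounds shown here, this shows that, on these two cores, the change carries over with no step beyond the scatter, but it rests on only two pairs read at one concentration, so it gives no potency for any compound and sets no rule for cores outside this set.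

The compounds shown carry only 3-methylbenzyl and 2-fluorobenzyl at this place, so it stays open what a plain benzyl group, a benzyl group bearing an amine or a carboxylic acid, or a longer chain ending in phenyl would give on either core. On these data alone, it also stays open whether any group at this place would give a step beyond the scatter, and whether such a step would then carry from the core of compound 1 to the core of compound 3.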